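This account rests on a few compounds, and the source may have more. Where it says the series, first, only, none or still open, it means among the compounds named here.

In a functional assay on HCT-116 cells (Homo sapiens) for cytotoxicity, read by sulforhodamine B assay, with a stated time of 24 h (on this read-out higher numbers stand for weaker inhibition and lower numbers for stronger inhibition), compound 1 (`Cc1ccc(/N=C2\C(=O)Nc3ccc(S(=O)(=O)N4CCOCC4)cc32)cc1`) gives 18900 nM and compound 2 (`O=C1Nc2ccc(S(=O)(=O)N3CCOCC3)cc2/C1=N/c1ccc(O)cc1`) gives 27300 nM, so compound 2 cannot be told apart from compound 1. Compound 3 (`CC(=O)N/N=C1\C(=O)Nc2ccc(S(=O)(=O)N3CCOCC3)cc21`) carries acetamido in place of 4-hydroxyphenyl on a double-bonded nitrogen. Among the compounds with values here, the only measured step, a 1.4-fold higher number from compound 1 to compound 2 (0.16 log units; within the scatter), exchanged methyl for hydroxy, whereas here the whole 4-hydroxyphenyl leaves, so it bears only loosely on this change. No step beyond the scatter is therefore expected in this assay, and the estimated step is a 1.4-fold lower number from compound 2 to compound 3 (0.14 log units; within the scatter). Compound 3 is estimated at 20000 nM, with an expected range of 7000 nM to 60000 nM.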

Compound 3, half-maximal inhibitory concentration: 29000 nM
For compound 3 the middle estimate is 1.5-fold (0.16 log units) below the measured one; the range from low to high includes it.
By their numbers in this assay, from the lowest: compounds 1, 2 and 3 (each within the scatter of the next).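

In this assay, the whole aromatic group on the double-bonded nitrogen gives way to acetamido with no step beyond the scatter (a 1.1-fold higher number from compound 2 to compound 3 (0.03 log units; within the scatter); a 1.5-fold higher number from compound 1 to compound 3 (0.19 log units; within the scatter)). Thus, among these three compounds, the number stays within the scatter even when the six-membered aromatic ring leaves this position, a larger change than the earlier exchange of methyl for hydroxy. Nothing available here accounts for this result. The compounds shown leave open whether a primary amine or a carboxylic acid on this nitrogen, or a longer chain in place of acetamido, would give a step beyond the scatter.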